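This account rests on a few compounds, and the source may have more. Where it says the series, first, only, none or still open, it means among the compounds named here.

Measured compounds:
- compound 1 `O=C(c1ccc(F)c(O)c1)c1ccc2cc(O)ccc2n1`: 71%
- compound 2 `O=C(c1ccc(F)c(O)c1)c1ccc2ccc(-c3nnn[nH]3)cc2n1`: 52%

In an assay for inhibition of 17-beta-hydroxysteroid dehydrogenase type 2 (Homo sapiens), read by HPLC, with a stated time of 10 min, tested at 1 uM (a higher number here means more inhibition at the concentration tested (going by the name of the read-out), a lower number less inhibition), compound 2 gives 52%, the lowest of the two numbers recorded; the nearest is compound 1, whose number is higher by a margin beyond the scatter. Among the compounds with values here, no step between measured compounds is counted, so the two values are simply noted side by side.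

Compound 3 `O=C(c1ccc(F)c(O)c1)c1ccc2ccccc2n1` is not yet measured. Its difference from compound 2 is hydrogen in place of 1H-tetrazol-5-yl on an aromatic carbon, on an aromatic carbon of a six-membered aromatic ring of carbon only, part of a fused system of two rings. Nothing measured shows what the bare ring does at this place, so the direction of the step is open; a small drop is expected, with wide uncertainty. The step of a number 10 percentage points lower from compound 2 to compound 3 (within the scatter) is the estimated change. Compound 3 is expected to give about 42% in this assay, within 15% to 68%.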

Compound 3, a percentage reported as inhibition, at one concentration (the size of the read-out at that concentration, not a potency): 76%
Compound 3: the middle estimate sits 34 percentage points below what was measured; measured number above the stated range.
By their numbers in this assay, from the lowest: compound 2; then compounds 1 and 3 (each within the scatter of the next).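

In this assay, hydrogen in place of 1H-tetrazol-5-yl gives a number 24 percentage points higher from compound 2 to compound 3 (beyond the scatter), so at this place on the ring the bare carbon is better than 1H-tetrazol-5-yl, and compound 3 reaches 76% with no substituent on the ring system. Hydrogen in place of hydroxy gives a number 5 percentage points higher from compound 1 to compound 3 (within the scatter), so the hydroxy of compound 1 brings no gain that can be told from the unsubstituted ring. Nothing available explains either step.

From the compounds shown here alone, whether the loss is specific to 1H-tetrazol-5-yl or would follow any substituent at this place remains open; a carboxylic acid, an amine or a methoxy group on the same carbon would separate the two readings. Each reading is also taken at a single concentration, so the potency of compound 3 remains undefined.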